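The source may report more compounds than this note shows. Statements on the series, on what has been measured and on what is new or still open speak of the compounds shown alone.

Measured so far:
Compound 1, `O=C(O)CCCCN(Cc1ccccc1)Cc1ccc2ccccc2c1`, gives 0% in an assay on HEK293 cells for binding affinity to Substance-K receptor (Rattus norvegicus), read by FRET, tested at 10 uM; a lower number here means less inhibition, a higher number more inhibition at the concentration tested (going by the name of the read-out).
Compound 2, `c1ccc(CN(Cc2ccc3ccccc3c2)c2ccccn2)cc1`, gives 17% in this assay.

Among the measured compounds shown here, of these two numbers compound 2 stands highest; its nearest neighbour is compound 1, and the single measured step, a number 17 percentage points higher from compound 1 to compound 2 (beyond the scatter), separates the two. Compound 3, `c1ccc(CN(Cc2ccc3ccccc3c2)c2ccncn2)cc1`, has not yet been measured. It differs from compound 2 in one place: pyrimidin-4-yl in place of pyridin-2-yl on an amine nitrogen. For the measured compounds named here, no measured step involves a pyrimidin-4-yl group, and the one step in hand, a number 17 percentage points higher from compound 1 to compound 2 (beyond the scatter), concerns a different exchange on the same amine nitrogen, so it offers little guidance on the present change. With no measured evidence pointing to a move beyond the scatter, the expected step in this assay is about a number 2 percentage points lower from compound 2 to compound 3 (within the scatter), which amounts to no change that could be told from repeat measurements. Compound 3 is therefore estimated at 15%, with a plausible range from 0% to 35%.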

Compound 3, a percentage reported as inhibition, at one concentration (the size of the read-out at that concentration, not a potency): 34%
Estimate against measurement, compound 3: 19 percentage points below, and the stated range covers the measured number.
By their numbers in this assay, from the lowest: compound 1; then compound 2; then compound 3.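

On the amine nitrogen, swapping one six-membered aromatic ring for another is not a neutral change in this assay: pyrimidin-4-yl in place of pyridin-2-yl gives a number 17 percentage points higher from compound 2 to compound 3 (beyond the scatter) and so shows that the make-up of the ring counts, not only the presence of an aromatic ring there. Both groups hold 6 heavy atoms and neither has a hydrogen-bond donor or a net charge, so the computed difference is that pyrimidin-4-yl has 2 hetero atoms and 2 hydrogen-bond acceptors where pyridin-2-yl has 1 of each. Against the 4-carboxybutyl chain, pyrimidin-4-yl gives a number 34 percentage points higher from compound 1 to compound 3 (beyond the scatter) and this is the widest gap yet on this nitrogen, but no measurement here bears on what lies behind either step.

Still open, on these data alone, is whether the placing of the ring nitrogens matters, which a pyrimidin-2-yl or pyrazin-2-yl group on the same amine nitrogen would test, and where a plain phenyl group, with no ring nitrogen at all, would fall. All three numbers also come from a single concentration, so they give the size of the inhibition there and not a potency for any of the compounds.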